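Arylethynyl in place of iodo on the shared core

The source may hold more compounds than are shown below. What is called first, only, known or untested is meant among the compounds shown, and "the series" means these compounds.

Two compounds were measured in an assay on CHO cells for displacement of a labelled ligand from adenosine receptor A1 (Homo sapiens); a higher number here means a weaker inhibitor, a lower number a stronger inhibitor:

Compound 1 `CCNC(=O)[C@H]1O[C@@H](n2cnc3c(NOC)nc(I)nc32)[C@H](O)[C@@H]1O` gives 53 nM.
Compound 2 `CNC(=O)[C@H]1O[C@@H](n2cnc3c(NOC)nc(C#Cc4ccc(F)cc4)nc32)[C@H](O)[C@@H]1O` gives 3000 nM.

Compound 1 stands as the lower of the two numbers; compound 2 differs from it in more than one place, and their values show a gap beyond the scatter. Compound 3 `CCNC(=O)[C@H]1O[C@@H](n2cnc3c(NOC)nc(C#Cc4ccc(C)cc4)nc32)[C@H](O)[C@@H]1O` carries 2-(4-methylphenyl)ethynyl in place of iodo on an aromatic carbon. Among the measured compounds shown here, with no single step between measured compounds to lean on, the move in this assay is expected to weaken binding, by a 15-fold higher number from compound 1 to compound 3 (1.18 log units; beyond the scatter), as an estimate. Compound 3 is therefore expected near 800 nM, within 150 nM to 4000 nM.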

Compound 3, inhibition constant: 1420 nM
For compound 3 the middle estimate is 1.8-fold (0.25 log units) below the measured one, and the stated range covers the measured number.
By their numbers in this assay, from the lowest: compound 1; then compound 3; then compound 2.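

In this assay, among the compounds shown here, the exchange of iodo for 2-(4-methylphenyl)ethynyl on the aromatic carbon between two ring nitrogen atoms gives the only single-place reading at this position, and binding weakens, with a 27-fold higher number from compound 1 to compound 3 (1.43 log units; beyond the scatter) as the size of the change. Unlike the gap between compound 1 and compound 2, this step can be tied to one place alone. Nothing shown explains the loss. The compounds leave open how an amine or a plain ethynyl group would fare on this carbon, and whether the aromatic ring or the triple bond carries the loss.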